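The compounds below may be only part of what the source reports. "The series", "measured", "known", "first", "only" and "open" are said of these compounds alone.

Three compounds built on one shared core have been run in a functional assay for agonist activity at 5-hydroxytryptamine receptor 4 (Cavia porcellus); on this read-out higher numbers stand for larger maximal responses and lower numbers for smaller maximal responses. Compound 1 `CN1CCN(CNC(=O)n2c(=O)n(C3CC3)c3ccccc32)CC1` gives 0.53 in this assay. Compound 2 `C=CCn1c(=O)n(C(=O)NCCN2CCN(C)CC2)c2ccccc21` gives 0.63 in this assay. Compound 3 `CCCN1CCN(CCNC(=O)n2c(=O)n(C(C)C)c3ccccc32)CC1` gives 0.68 in this assay. Among these three numbers, the one for compound 2 is the second highest, yet neither the gap to compound 3 nor the gap to compound 1 reaches beyond the usual scatter of repeated measurements, so the three compounds cannot be told apart on this read-out.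

Compound 4 `CCCn1c(=O)n(C(=O)NCCN2CCN(C)CC2)c2ccccc21` has not yet been measured. Set against compound 2, it differs in one place: ethyl in place of vinyl on a saturated chain carbon bound to an aromatic nitrogen. Among the compounds with values here, no pair of measured compounds shows this same change, so there is no measured step to lean on. The change keeps the count of heavy atoms, the absence of a ring, and the absence of donors and acceptors; only the double bond outside aromatic rings is lost.

Given how close the three measured compounds sit to one another, compound 4 is expected to land near compound 2, with the step from compound 2 to compound 4 estimated as a number 0.010 higher from compound 2 to compound 4 (within the scatter), which is not beyond the scatter. Compound 4 is therefore estimated to give about 0.64 in this assay, most likely between 0.5 and 0.78.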

Compound 4, intrinsic activity: the largest response reached, as a fraction of the reference agonist's: 0.48
For compound 4 the middle estimate is 0.16 above the measured one, outside the stated range (below it).
By their numbers in this assay, from the lowest: compounds 4, 1, 2 and 3 (each within the scatter of the next, the first and the last beyond it).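

Allyl to propyl, read as ethyl in place of vinyl on a saturated chain carbon bound to an aromatic nitrogen, is the only single change shown, and in this assay it gives a number 0.15 lower from compound 2 to compound 4 (beyond the scatter). Within the data shown here, this is the first sign that the group at this place can move the maximal response by more than the scatter, which the earlier compounds could not show, since no two of them differ in one place only. Vinyl and ethyl have the same count of heavy atoms, and neither has a ring, a donor, an acceptor or a net charge, so the double bond outside aromatic rings is the only counted feature that leaves, though nothing at hand bears on the reason for the step.

From the compounds shown here alone, whether any unsaturated group at this place would match the allyl of compound 2 remains open, as a propargyl or a benzyl group would be needed to test it. Going by these compounds, how a longer chain such as butyl would compare with the propyl of compound 4 also remains open, and compound 1 and compound 3 differ from these two in more than one place, so they cannot settle either question.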